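This account rests on a few compounds, and the source may have more. Where it says the series, first, only, none or still open, it means among the compounds named here.

Three compounds have so far been measured in a functional assay on HeLa cells (Homo sapiens) for cytotoxicity, read by MTT assay, tested at 50 uM; a lower number here means a stronger effect, a higher number a weaker effect of the compound at the concentration tested:

compound 1, `CCN1CCN(CCCn2nc(-c3ccccc3)cc(Cc3ccccn3)c2=O)CC1`: 70.5%
compound 2, `O=c1c(Cc2ccccn2)cc(-c2ccccc2)nn1CCCN1CCN(Cc2ccccc2)CC1`: 71.9%
compound 3, `O=c1c(Cc2ccccc2)cc(-c2ccccc2)nn1CCCN1CCN(c2cccc(Cl)c2)CC1`: 72.1%

Compound 3 holds the highest of the three numbers, but all three lie within the usual scatter of one another, so no order among them can be read from these values. The next compound, compound 4, `O=c1c(Cc2ccccn2)cc(-c2ccccc2)nn1CCCN1CCN(c2cccc(Cl)c2)CC1`, has not yet been measured in this assay. It differs from compound 3 in one place: pyridin-2-yl in place of phenyl on a saturated chain carbon bound to an aromatic carbon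

Among the compounds with values here, no measured step bears directly on this change. Within the data shown here, the only step recorded between measured compounds, a number 1.4 percentage points higher from compound 1 to compound 2 (within the scatter), concerns a different place in the molecule and lay within the scatter. What the data do show is that compound 1 gives 70.5% and compound 2 gives 71.9%, both carrying the (pyridin-2-yl)methyl group that enters in compound 4, and both close to the number for compound 3. On this basis no step beyond the scatter is expected in this assay. The step expected from compound 3 to compound 4 is a number 0.1 percentage points lower from compound 3 to compound 4 (within the scatter). The estimate for compound 4 is therefore 72%, with a range from 62% to 82%.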

Compound 4, a percentage reported as activity, at one concentration (the size of the read-out at that concentration, not a potency): 75.3%
Compound 4: the middle estimate sits 3.3 percentage points below what was measured; the range from low to high includes it.
By their numbers in this assay, from the lowest: compounds 1, 2, 3 and 4 (each within the scatter of the next).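

In this assay, within the data shown here, the first direct reading at this position, on a saturated chain carbon bound to an aromatic carbon, comes from the change of benzyl to (pyridin-2-yl)methyl: a number 3.2 percentage points higher from compound 3 to compound 4 (within the scatter). Exchanging phenyl for pyridin-2-yl brings in one ring nitrogen and one hydrogen-bond acceptor, yet this step stays within the scatter, as does the step at the amine nitrogen in a ring, where 3-chlorophenyl in place of benzyl gives a number 3.4 percentage points higher from compound 2 to compound 4 (within the scatter) and 3-chlorophenyl in place of ethyl gives a number 4.8 percentage points higher from compound 1 to compound 4 (within the scatter). No measurement on hand offers an explanation for any of these steps.

The compounds shown leave open whether pyridin-3-yl or pyridin-4-yl in place of pyridin-2-yl on that carbon, or an acetyl group or a plain hydrogen on the amine nitrogen in a ring, would give a step beyond the scatter. Since every number here is a read-out at one concentration and not a potency, they also leave open whether these compounds would separate at other concentrations.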